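Swapping a Benzyl for a Basic Side Chain

The source may report more compounds than this note shows. Statements on the series, on what has been measured and on what is new or still open speak of the compounds shown alone.

Compound 1, with the structure `O=C(Nc1ccc(C(=O)N2CCCN(Cc3ccccc3)c3sccc32)cc1)c1ccccc1-c1ccccc1`, was tested in an assay on CHO cells for inhibition of Vasopressin V2 receptor (Homo sapiens), read by radioligand binding (on this read-out higher numbers stand for weaker inhibition and lower numbers for stronger inhibition), where compound 1 gives 80 nM. Among the compounds with values here, of the two compounds measured in this assay, compound 1 has the highest number; the only other compound, compound 2 with structure `CN(C)C1CCN(C(=O)CCCOc2cc(C(=O)N3CCCCc4sccc43)ccc2NC(=O)c2ccccc2-c2ccccc2)CC1`, gives 20 nM in this assay, a difference that goes beyond the usual scatter. Compound 2 differs from compound 1 in several places at once, so no single structural cause can be read from that pair.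

Compound 3, whose structure is `O=C(Nc1ccc(C(=O)N2CCCN(CCN3CCCC3)c3sccc32)cc1)c1ccccc1-c1ccccc1`, has not yet been measured. It differs from compound 1 in one place: (pyrrolidin-1-yl)methyl in place of phenyl on a saturated chain carbon bound to a nitrogen on an aromatic ring in a ring. Within the data shown here, since no step between two measured compounds carries this change alone, the expected size of the step rests on the two measured values only. The expected step from compound 1 to compound 3 is a 2.0-fold lower number from compound 1 to compound 3 (0.30 log units; within the scatter), a modest move toward a lower number, roughly in keeping with the value of compound 2 in this assay. Compound 3 is estimated to give 40 nM, within a range from 10 nM to 160 nM.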

Compound 3, half-maximal inhibitory concentration: 200 nM
For compound 3 the middle estimate is 5.0-fold (0.70 log units) below the measured one, and the stated range ends below it.
By their numbers in this assay, from the lowest: compound 2; then compound 1; then compound 3.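

Within the data shown here, compound 1 and compound 3 give the first comparison in this assay where only one place changes: on a saturated chain carbon bound to a nitrogen on an aromatic ring in a ring, benzyl gives way to 2-(pyrrolidin-1-yl)ethyl, with a 2.5-fold higher number from compound 1 to compound 3 (0.40 log units; beyond the scatter). This modest step is a real loss of inhibition, so on this core the non-aromatic, nitrogen-bearing group does not match the phenyl ring it replaces, even though the two groups are equal in heavy atoms. Nothing measured here explains why this swap weakens inhibition.

A single pair cannot separate the effect of losing the aromatic ring from that of adding the ring nitrogen, and a carbon-only group such as 2-cyclopentylethyl would be needed to tell them apart. On these data alone, it also remains open whether a 2-(morpholin-4-yl)ethyl group, or a longer chain ending in the same pyrrolidine ring, would sit closer to compound 1 or further from it.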